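A chlorothiophene in place of a thiadiazolone

A few compounds are considered here, and "the series" means these few. Any claim that something is new, unique, unknown or untested is made for them only; others in the source may bear on it.

Compound 1 `O=c1[nH]nc(C[S+]([O-])C(c2ccccc2)c2ccccc2)s1` is one of three related sulfoxides. In an assay on HEK293 cells for inhibition of sodium-dependent dopamine transporter (Homo sapiens), read by scintillation counting, with stated times of 5 min and 1 min (a higher number here means a weaker inhibitor, a lower number a stronger inhibitor), compound 1 gives 38100 nM, the second highest of the three numbers. Compound 3 `CC(C)c1nnsc1C[S+]([O-])C(c1ccccc1)c1ccccc1` gives 69100 nM, and the step of a 1.8-fold higher number from compound 1 to compound 3 (0.26 log units; within the scatter) shows that exchanging one small heteroaromatic ring for another made little difference here. Compound 2 `[O-][S+](Cc1cccs1)C(c1ccc(F)cc1)c1ccc(F)cc1`, which carries a thiophen-2-yl ring and two fluorines, gives 4000 nM, a lower number than compound 1 and beyond the scatter.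

Among the measured compounds shown here, compound 4 `[O-][S+](Cc1ccc(Cl)s1)C(c1ccccc1)c1ccccc1` has not been measured. a group of 6 heavy atoms (4 carbon, 1 sulfur, 1 chlorine; one five-membered aromatic ring with 1 hetero atom) in place of a group of 6 heavy atoms (2 carbon, 2 nitrogen, 1 oxygen, 1 sulfur; one five-membered aromatic ring with 3 hetero atoms), on a saturated chain carbon bound to a sulfur No measured step covers exactly this change. The step from compound 1 to compound 3 stayed within the scatter, while compound 2 shows that a thiophene-bearing analogue can reach a lower number, although its two fluorines are absent from compound 4. The expected step is a 5.4-fold lower number from compound 1 to compound 4 (0.74 log units; beyond the scatter), toward a lower number. Compound 4 is therefore estimated at 7000 nM, within a range from 1500 nM to 30000 nM.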

Compound 4, half-maximal inhibitory concentration: 12800 nM
Compound 4: the middle estimate sits 1.8-fold (0.26 log units) below what was measured, within the range that was stated.
By their numbers in this assay, from the lowest: compound 2; then compound 4; then compounds 1 and 3 (each within the scatter of the next).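

Changing the ring on the saturated chain carbon bound to a sulfur can clearly move the number: 5-chlorothiophen-2-yl gives a 3.0-fold lower number from compound 1 to compound 4 (0.47 log units; beyond the scatter), and in place of 4-isopropyl-1,2,3-thiadiazol-5-yl it gives a 5.4-fold lower number from compound 3 to compound 4 (0.73 log units; beyond the scatter). Compounds 1 and 3, whose rings each hold three hetero atoms, stand within the scatter of each other, while compound 4, with its ring of one hetero atom, is set apart from both. No measurement shown explains why this ring gives a lower number.

As far as these compounds go, how much of the change belongs to the chlorine and how much to the thiophene ring stays open, and compound 2 cannot settle it, as it differs from compound 4 in more than one place. Also open, from the compounds shown here alone, is how a bromine or a methyl group would compare with the chlorine on this ring.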